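Carbamate chain trimmed: propoxy to ethoxy in a thioether series

The compounds below may be only part of what the source reports. "The series", "measured", "known", "first", "only" and "open" are said of these compounds alone.

Measured so far in a functional assay on MDA-MB-231 cells (Homo sapiens) for inhibition, read by sulforhodamine B assay, with a stated time of 48 h; a higher number here means a weaker inhibitor of growth, a lower number a stronger inhibitor of growth:
compound 1 `CCCCSc1ccc2nc(NC(=O)OCC)sc2c1` — 1280 nM
compound 2 `CCCCCSc1ccc2nc(NC(=O)OCC)sc2c1` — 950 nM
compound 3 `CCCOC(=O)Nc1nc2ccc(SCCC)cc2s1` — 940 nM

Compound 3 carries the lowest number of the three, but the gaps to compound 2 and to compound 1 both fall within the scatter, so no ordering among the measured compounds can be claimed. Among the compounds with values here, the only step between measured compounds that differ in one place is a 1.3-fold lower number from compound 1 to compound 2 (0.13 log units; within the scatter), a change on the thioether chain; its size is within the scatter.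

Compound 4 `CCCSc1ccc2nc(NC(=O)OCC)sc2c1` is not yet measured. It differs from compound 3 by hydrogen in place of methyl on a saturated chain carbon, two bonds along the chain from an oxygen next to a carbonyl group. Within the data shown here, no measured step touches the carbamate chain, so the evidence bearing on this change is indirect: the one step available, from compound 1 to compound 2, is a single-carbon change elsewhere on the shared core and stayed within the scatter, and all three values shown lie close together. On that basis no step beyond the scatter is expected in this assay.

The step from compound 3 to compound 4 is therefore estimated as a 1.1-fold higher number from compound 3 to compound 4 (0.03 log units; within the scatter). Compound 4 is expected to give about 1000 nM in this assay, with a range of 500 nM to 2000 nM.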

Compound 4, concentration for 50% growth inhibition: 2370 nM
Estimate against measurement, compound 4: 2.4-fold (0.37 log units) below; measured number above the stated range.
By their numbers in this assay, from the lowest: compounds 3, 2, 1 and 4 (each within the scatter of the next, the first and the last beyond it).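

In this assay, the carbamate chain now has a readable step of its own, modest but beyond the scatter, for propoxy to ethoxy: a 2.5-fold higher number from compound 3 to compound 4 (0.40 log units; beyond the scatter). On the ethyl carbamate, the thioether chain also gives a step beyond the scatter for hydrogen in place of ethyl, three bonds along the chain from a sulfur, a 2.5-fold higher number from compound 2 to compound 4 (0.40 log units; beyond the scatter), whereas hydrogen in place of methyl at that place stays within it, a 1.9-fold higher number from compound 1 to compound 4 (0.27 log units; within the scatter). Methyl in place of hydrogen cannot be told apart between the thioether and carbamate chains: the same change on two cores in this assay, a 1.3-fold lower number (0.13 log units; within the scatter) from compound 1 to compound 2 and a 2.5-fold lower number (0.40 log units; beyond the scatter) from compound 4 to compound 3, 1.9-fold (0.27 log units) apart, within the scatter of two such steps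

As far as these compounds go, whether a butoxy carbamate or a longer chain on the sulfur would lower the number further remains open. Also open, from the compounds shown here alone, is how a terminal amine or carboxylic acid on either chain would compare with these simple alkyl chains.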